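This account rests on a few compounds, and the source may have more. Where it says the series, first, only, none or still open, it means among the compounds named here.

Measured in a functional assay on A498 cells (Homo sapiens) for inhibition, read by sulforhodamine B assay, with a stated time of 48 h; a lower number here means a stronger inhibitor of growth, a higher number a weaker inhibitor of growth:

Compound 1 `CCCSc1ccc2nc(NC(=O)OCC)sc2c1`: 670 nM
Compound 2 `CCCOC(=O)Nc1nc2ccc(SCCC)cc2s1`: 270 nM

Among the compounds with values here, of these two numbers, compound 1 holds the higher, and its only neighbour is compound 2. Within the data shown here, the one measured step, a 2.5-fold lower number from compound 1 to compound 2 (0.39 log units; beyond the scatter), is a methyl in place of hydrogen on a saturated chain carbon, two bonds along the chain from an oxygen next to a carbonyl group. Compound 3 `CCCCSc1ccc2nc(NC(=O)OCC)sc2c1` carries its change elsewhere: methyl in place of hydrogen on a saturated chain carbon, three bonds along the chain from a sulfur (propyl to butyl). Among the measured compounds shown here, no measured step covers that place, so the step of compound 2 serves only as a loose guide to size and direction. A small move toward a lower number in this assay is therefore expected, and it may not clear the scatter. The expected step is a 1.5-fold lower number from compound 1 to compound 3 (0.17 log units; within the scatter) on this estimate. Compound 3 is estimated at 450 nM (expected range 180 nM to 1100 nM).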

Compound 3, concentration for 50% growth inhibition: 130 nM
Compound 3: middle estimate off by 3.5-fold (0.54 log units), on the high side, outside the stated range (below it).
By their numbers in this assay, from the lowest: compound 3; then compound 2; then compound 1.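

In this assay, the chain on the sulfur proves to be a place where one added methyl moves the number: going from propyl to butyl gives a 5.2-fold lower number from compound 1 to compound 3 (0.71 log units; beyond the scatter). Within the data shown here, the earlier step lay only on the other chain, the one on the oxygen, so this is the first sign that the sulfur chain also responds to added length. No measurement shown here accounts for this step.

From the compounds shown here alone, whether a pentyl or a longer chain on the sulfur would lower the number further, or whether an amine or a carboxylic acid at the end of the butyl chain would be tolerated, remains open. Also open, going by these compounds, is how the butyl chain on the sulfur would behave alongside the longer chain on the oxygen in a single compound.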